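Cell tolerance across a benzyl-substituted series

The compounds below may be only part of what the source reports. "The series", "measured", "known", "first", "only" and "open" are said of these compounds alone.

Compound 1, `Cc1c(Cc2ccc(F)cc2)c(=O)oc2cc(OCC(O)CN3CCC(C(N)=O)CC3)ccc12`, gives 89300 nM in an ADME assay on A549 cells (Homo sapiens) for cytotoxicity, read by CellTiter-Glo; a lower number here means that less compound is tolerated, a higher number that more compound is tolerated. Compound 2, `Cc1c(Cc2ccc(Cl)cc2)c(=O)oc2cc(OCC(O)CN3CCC(C(N)=O)CC3)ccc12`, gives 40000 nM in this assay. Compound 3, `Cc1cc(F)ccc1Cc1c(C)c2ccc(OCC(O)CN3CCC(C(N)=O)CC3)cc2oc1=O`, reaches only the limit of this assay, > 100000 nM.

Compound 3 therefore stands at the top of the measured set, but only as a limit, not a number (the limit of > 100000 nM in this assay, at which 1 of the 3 values shown sits). Among the compounds with values here, two measured steps bear on what follows. Swapping one halogen for another gave a 2.2-fold lower number from compound 1 to compound 2 (0.35 log units; beyond the scatter). Replacing the whole ring gave an at least 2.5-fold higher number from compound 2 to compound 3 (0.39 log units; beyond the scatter), which reached the limit. Compound 4, `Cc1c(Cc2ccc(OC(F)(F)F)cc2)c(=O)oc2cc(OCC(O)CN3CCC(C(N)=O)CC3)ccc12`, differs from compound 3 by 4-(trifluoromethoxy)phenyl in place of 4-fluoro-2-methylphenyl on a saturated chain carbon bound to an aromatic carbon. Compound 4 thus lacks the methyl that set compound 3 apart from compound 1, and carries a single substituent as compounds 1 and 2 do. On that basis compound 4 is expected to fall back from the limit toward the numbers of compounds 1 and 2, a step of an at least 2.0-fold lower number from compound 3 to compound 4 (0.30 log units; that floor lies within the scatter). Compound 4 is estimated at 50000 nM, within a range of 20000 nM to 150000 nM.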

Compound 4, half-maximal cytotoxic concentration: 68200 nM
Compound 4: middle estimate off by 1.4-fold (0.13 log units), on the low side; the range from low to high includes it.
By their numbers in this assay, from the lowest: compounds 2, 4 and 1 (each within the scatter of the next, the first and the last beyond it). At a limit, above all of these: compound 3.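

In this assay, trifluoromethoxy in place of a halogen on this aromatic carbon gives a 1.3-fold lower number from compound 1 to compound 4 (0.12 log units; within the scatter) and a 1.7-fold higher number from compound 2 to compound 4 (0.23 log units; within the scatter). Compound 4 therefore cannot be told apart from either halogen compound, even though those two are separated by a 2.2-fold lower number from compound 1 to compound 2 (0.35 log units; beyond the scatter), a step beyond the scatter. The remaining step, an at least 1.4-fold lower number from compound 3 to compound 4 (0.16 log units; that floor lies within the scatter), rests on a limit and not on a number: the limit of > 100000 nM in this assay, at which 1 of the 4 values shown sits.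

From the compounds shown here alone, how far the true value of compound 3 lies from that limit stays open, and with it the real size of the change from 4-fluoro-2-methylphenyl to 4-(trifluoromethoxy)phenyl. Also open, going by these compounds, is how the number would respond to an amine or a carboxylic acid on this aromatic carbon in place of the halogen or trifluoromethoxy.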